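Shortening the benzyl arm to phenyl on the imidazole

A few compounds are considered here, and "the series" means these few. Any claim that something is new, unique, unknown or untested is made for them only; others in the source may bear on it.

Measured compounds in an in vitro functional assay on cells for agonist activity at Bombesin receptor subtype-3 (Mus musculus), read by luminescence and calcium flux; on this read-out higher numbers stand for an effect only at larger amounts of compound and lower numbers for an effect already at smaller amounts:
compound 1 `COc1cccc(Cc2cnc(CCc3ccc(-c4ccccc4C(=O)O)cc3)[nH]2)c1`, 79 nM
compound 2 `O=C(O)c1ccccc1-c1ccc(CCc2ncc(Cc3ccccc3Cl)[nH]2)cc1`, 22 nM
compound 3 `O=C(O)c1ccccc1-c1ccc(CCc2ncc(Cc3cccc(F)c3)[nH]2)cc1`, 7.9 nM

Compound 3 holds the lowest number of the three. Its nearest neighbour is compound 2, and the step of a 2.8-fold lower number from compound 2 to compound 3 (0.44 log units; beyond the scatter) lies beyond the scatter; the furthest is compound 1, with a 10-fold lower number from compound 1 to compound 3 (1.00 log units; beyond the scatter). All three measured compounds share the same core and differ only in the aromatic ring on the saturated chain carbon.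

Compound 4 `O=C(O)c1ccccc1-c1ccc(CCc2ncc(-c3ccccc3)[nH]2)cc1` is not yet measured. It differs from compound 3 in this way: phenyl in place of 3-fluorobenzyl on an aromatic carbon. So the change removes both the fluorine and the saturated carbon link, leaving the phenyl attached directly to the five-membered ring.

Within the data shown here, none of the measured steps covers this change. The steps of a 3.6-fold lower number from compound 1 to compound 2 (0.56 log units; beyond the scatter), a 10-fold lower number from compound 1 to compound 3 (1.00 log units; beyond the scatter) and a 2.8-fold lower number from compound 2 to compound 3 (0.44 log units; beyond the scatter) only swap substituents on the pendant ring while the link is kept, and they show that this part of the molecule moves the read-out by modest amounts. Removing the link is a different kind of change, and the data give no direction for it.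

Compound 4 is therefore expected to give 40 nM in this assay, within a wide range from 8 nM to 300 nM, the step of a 5.1-fold higher number from compound 3 to compound 4 (0.70 log units; beyond the scatter) being an estimate rather than a measured trend.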

Compound 4, half-maximal effective concentration: 872 nM
Estimate against measurement, compound 4: 22-fold (1.34 log units) below, and the stated range ends below it.
By their numbers in this assay, from the lowest: compound 3; then compound 2; then compound 1; then compound 4.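

In this assay, among these compounds, the aromatic carbon of the five-membered aromatic ring proves far more sensitive to the loss of the saturated carbon link than the pendant ring was to any swap of its substituents: a 110-fold higher number from compound 3 to compound 4 (2.04 log units; beyond the scatter) is a large step, whereas the earlier steps were all modest. The effect holds across every benzyl compound shown, with a 40-fold higher number from compound 2 to compound 4 (1.60 log units; beyond the scatter) and an 11-fold higher number from compound 1 to compound 4 (1.04 log units; beyond the scatter) also large, so that even compound 1, the highest of the three earlier numbers, lies well on the favourable side of the directly attached phenyl of compound 4. No available evidence accounts for the size of this shift.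

The compounds shown leave open how the step divides between the lost link and the lost ring substituent, as the change from 3-fluorobenzyl to phenyl removes both at once and an unsubstituted benzyl group, which would separate the two, does not stand among them. They also leave open whether a longer chain, such as 2-phenylethyl, would carry the read-out further in the same direction or reverse it.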